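The source may report more compounds than this note shows. Statements on the series, on what has been measured and on what is new or still open speak of the compounds shown alone.

Going by the values given here, in an ADME assay on HEK293 cells (Homo sapiens) for cytotoxicity, read by resazurin assay, with a stated time of 48 h (on this read-out higher numbers stand for lower toxicity in this test and lower numbers for higher toxicity in this test), compound 1 `O=S(=O)(Nc1ccc2oc(-c3ccccc3)nc2c1)c1cccc(F)c1` gives 68000 nM, the only plain number among the three measured values. Compound 2 `O=S(=O)(Nc1ccc(-c2nc3ccccc3o2)cc1)c1cccc(O)c1` reaches only the limit of > 100000 nM. Compound 3 `COc1ccccc1S(=O)(=O)Nc1ccc(-c2nc3ccccc3o2)cc1` likewise reaches only the limit of > 100000 nM. Compound 4 `CCc1ccc(S(=O)(=O)Nc2ccc3oc(-c4ccccc4)nc3c2)cc1` differs from compound 1 by 4-ethylphenyl in place of 3-fluorophenyl on a sulfonyl sulfur. Among the compounds with values here, the one measured step at the same place is a step that the two limits leave unreadable from compound 2 to compound 3, and it is unreadable because both its ends sit at the limit of > 100000 nM in this assay, at which 2 of the 3 values shown sit. Within the data shown here, no measured step therefore gives a direction for this change, and the values shown hold no sign of a large shift. Compound 4 is accordingly expected near 80000 nM, with a range from 30000 nM to 200000 nM. The expected step of a 1.2-fold higher number from compound 1 to compound 4 (0.07 log units; within the scatter) is small, within the usual scatter.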

Compound 4, half-maximal cytotoxic concentration: 81000 nM
Beside the measured number, compound 4's estimate is 1.0-fold (0.01 log units) below it; the measured number falls inside the stated range.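

In this assay, going by these compounds alone, the change on the sulfonyl sulfur gives a 1.2-fold higher number from compound 1 to compound 4 (0.08 log units; within the scatter), the first readable step at this position, and it shows that 4-ethylphenyl and 3-fluorophenyl cannot be told apart here. Compounds 2 and 3 could not show this, because neither gives a plain number: the limit of > 100000 nM in this assay, at which 2 of the 4 values shown sit.

One step on one core says little about the position as a whole. Going by these compounds, whether an amine or a carboxylic acid on this phenyl ring, or a longer chain in place of the ethyl, would move the number beyond the scatter remains open.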